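The source may hold more compounds than are shown below. What is called first, only, known or untested is meant among the compounds shown, and "the series" means these compounds.

Compound 3 `O=C(NO)c1ccc(NCc2nc(-c3ccc(Br)cc3)nn2-c2ccccc2)cc1` gives 54.7% in an assay on Sf9 cells for inhibition of protein deacetylase HDAC6 (Homo sapiens), read by fluorescence, with a stated time of 40 min, tested at 100 nM (on this read-out higher numbers stand for more inhibition at the one concentration tested (going by the name of the read-out) and lower numbers for less inhibition), the lowest of the three numbers recorded so far. Its nearest neighbour is compound 1 `Cc1ccc(-c2nc(CNc3ccc(C(=O)NO)cc3)n(-c3ccccc3)n2)cc1`, which gives 62.2%, and the step of a number 7.5 percentage points lower from compound 1 to compound 3 (within the scatter). Compound 2 `COc1ccc(-c2nc(CNc3ccc(C(=O)NO)cc3)n(-c3ccccc3)n2)cc1` gives 77.6%, and the step of a number 22.9 percentage points lower from compound 2 to compound 3 (beyond the scatter). Compound 4 `O=C(NO)c1ccc(NCc2nc(-c3ccc(Cl)cc3)nn2-c2ccccc2)cc1` differs from compound 3 by chloro in place of bromo on an aromatic carbon. Going by the values given here, no measured step exchanges one halogen for another at this position; the two steps that touch it both replace a methyl or a methoxy with bromo, and neither involves chloro. Among the compounds with values here, with no precedent for this exchange, the expected step of a number 0.3 percentage points higher from compound 3 to compound 4 (within the scatter) is none beyond the scatter. Compound 4 is therefore estimated at 55%, with a range from 40% to 70%.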

Compound 4, a percentage reported as inhibition, at one concentration (the size of the read-out at that concentration, not a potency): 67.2%
Compound 4: middle estimate off by 12.2 percentage points, on the low side; low and high end bracket the measured number.
By their numbers in this assay, from the lowest: compounds 3, 1 and 4 (each within the scatter of the next, the first and the last beyond it); then compound 2.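

Going by these compounds alone, compound 4 gives the first exchange of one halogen for another at this position, and it shows a number 12.5 percentage points higher from compound 3 to compound 4 (beyond the scatter) so the two halogens do not read alike here. Chloro does not reach methoxy, with a number 10.4 percentage points lower from compound 2 to compound 4 (beyond the scatter) while the comparison with methyl gives a number 5 percentage points higher from compound 1 to compound 4 (within the scatter) and so separates nothing. No evidence is at hand on what lies behind these steps. On these data alone, it stays open where fluoro, an amine or a carboxylic acid in the same place would fall, and whether the gap between chloro and bromo holds with other groups on the shared core.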